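Acetyl in Place of Fluoro: Expected Effect on Cell Growth

The source may report more compounds than this note shows. Statements on the series, on what has been measured and on what is new or still open speak of the compounds shown alone.

Measured compounds:
- compound 1, `Cc1cc(C)c(NC(=O)CCc2cccc3c2B(O)OC3)c(C)c1`: 64000 nM
- compound 2, `O=C(CCc1cccc2c1B(O)OC2)Nc1cccc(-c2cccc(F)c2)c1`: 460 nM

Of the compounds shown here, two have been tested in a functional assay on HCT-116 cells (Homo sapiens) for antiproliferative activity, read by MTT assay, with a stated time of 72 h; on this read-out higher numbers stand for weaker inhibition and lower numbers for stronger inhibition. Compound 1 gives 64000 nM, while compound 2 gives 460 nM. For the measured compounds named here, of these two numbers, the one for compound 2 is the lower, so compound 2 inhibits cell growth more strongly, and the gap to compound 1 is far wider than the scatter of repeated measurements. The two compounds differ in more than one place, so no single change can be read off between them.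

The next compound, compound 3 `CC(=O)c1cccc(-c2cccc(NC(=O)CCc3cccc4c3B(O)OC4)c2)c1`, keeps everything in compound 2 except one group: acetyl in place of fluoro on an aromatic carbon, so that 3-fluorophenyl becomes 3-acetylphenyl. Going by the values given here, there is no measured pair here showing what such an exchange does in this assay. In that situation the expectation is a step of modest size, likely a slight weakening, with no change beyond the scatter also quite possible; the step expected from compound 2 to compound 3 is a 1.5-fold higher number from compound 2 to compound 3 (0.18 log units; within the scatter). Compound 3 is therefore estimated at 700 nM, within a range of 200 nM to 2500 nM.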

Compound 3, half-maximal inhibitory concentration: 86 nM
Compound 3: middle estimate off by 8.1-fold (0.91 log units), on the high side; measured number outside the range, below it.
By their numbers in this assay, from the lowest: compound 3; then compound 2; then compound 1.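

Going from 3-fluorophenyl to 3-acetylphenyl in this assay gives a 5.3-fold lower number from compound 2 to compound 3 (0.73 log units; beyond the scatter) and is the first single change in this set whose size can be read, showing that the group at this position affects the result. Acetyl brings three heavy atoms where fluoro has one, and one hydrogen-bond acceptor where fluoro counts none, yet compound 3 inhibits cell growth more strongly than compound 2, so in this one pair a group larger than a single atom is accepted at this position. No measurement shown explains why the number falls, so this step records an effect and not its cause.

The compounds shown leave open whether the gain belongs to acetyl in particular or would also appear with an amine, a carboxylic acid or a nitrile at this same place on the ring. They also leave open whether the same exchange would move the number in the same direction if the amide-linked part of the molecule carried a different aromatic group, as it does in compound 1.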